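A few compounds are considered here, and "the series" means these few. Any claim that something is new, unique, unknown or untested is made for them only; others in the source may bear on it.

Working notes on the series. The shared core carries compound 1 `COc1nc(-c2cc3ccccc3o2)cc(-c2ccccc2)c1C#N`, compound 2 `CCOc1nc(-c2cc3ccccc3o2)cc(-c2ccccc2)c1C#N` and compound 3 `CCOc1nc(-c2cc3ccccc3o2)cc(-c2cc(OC)ccc2OC)c1C#N`. In a functional assay on aorta (strain Wistar) for inhibition, with Thoracic aorta (Rattus norvegicus) as the target (on this read-out higher numbers stand for weaker inhibition and lower numbers for stronger inhibition), compound 1 gives 232000 nM; compound 2 gives 310000 nM and compound 3 gives 327000 nM. The step of a 1.3-fold higher number from compound 1 to compound 2 (0.13 log units; within the scatter) and the step of a 1.1-fold higher number from compound 2 to compound 3 (0.02 log units; within the scatter) are both within the scatter, so compound 1 sits alongside both of the others with no separation that can be read as a real difference.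

Compound 4 `COc1nc(-c2cc3ccccc3o2)cc(-c2ccc(C)o2)c1C#N` is not yet measured in this assay. Relative to compound 1 the change is 5-methylfuran-2-yl in place of phenyl on an aromatic carbon. For the measured compounds named here, of the measured steps, only the one from compound 2 to compound 3 touches the same position, where 2,5-dimethoxyphenyl in place of phenyl on an aromatic carbon gave a 1.1-fold higher number from compound 2 to compound 3 (0.02 log units; within the scatter). That step is within the scatter, and nothing in the series shows a replacement of phenyl by a five-membered aromatic ring with 1 hetero atom at this place, so there is no basis for expecting a step beyond the scatter in this assay in either direction.

For compound 4 the expected value is therefore 250000 nM, with a range of 90000 nM to 700000 nM, which means an expected step of a 1.1-fold higher number from compound 1 to compound 4 (0.03 log units; within the scatter).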

Compound 4, half-maximal inhibitory concentration: 285000 nM
For compound 4 the middle estimate is 1.1-fold (0.06 log units) below the measured one; the range from low to high includes it.
By their numbers in this assay, from the lowest: compounds 1, 4, 2 and 3 (each within the scatter of the next).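

For the compounds shown here, the oxygen-containing five-membered ring gives the first read on this place, on an aromatic carbon opposite the ring nitrogen, where the earlier compounds carried only phenyl or 2,5-dimethoxyphenyl. In this assay, 5-methylfuran-2-yl in place of phenyl gives a 1.2-fold higher number from compound 1 to compound 4 (0.09 log units; within the scatter), so exchanging the six-membered aromatic ring of carbon only for a five-membered aromatic ring with a hetero atom, which also brings in a hydrogen-bond acceptor, produces no separation that can be read as a real difference. No supporting measurement bears on the reason for this outcome.

The compounds shown leave open how much the ring and its methyl each contribute, since unsubstituted furan-2-yl would be needed to separate them, and whether an amine or a carboxylic acid on the phenyl at this place would give a step beyond the scatter. They also leave open whether a longer chain, such as butoxy, in place of the methoxy group would move the number outside the scatter, because every change seen so far stays within it.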